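Carboxy in place of 2-hydroxyethyl: working notes

This account rests on a few compounds, and the source may have more. Where it says the series, first, only, none or still open, it means among the compounds named here.

Measured in a functional assay on OVCAR-8 cells (Homo sapiens) for antiproliferative activity; a higher number here means a weaker inhibitor, a lower number a stronger inhibitor:
Compound 1 `Cn1ncc(Cl)c1-c1cc(C(=O)N[C@@H]2CN[C@H](CCNS(C)(=O)=O)C[C@H]2c2ccc(F)c(F)c2)oc1Cl`: 1530 nM
Compound 2 `Cn1ncc(Cl)c1-c1cc(C(=O)N[C@@H]2CN[C@H](CCCO)C[C@H]2c2ccc(Cl)c(Cl)c2)oc1Cl`: 600 nM

Compound 2, at 600 nM, holds the lower of the two numbers in this assay. Compound 1, at 1530 nM, lies above it by more than the usual scatter. The two compounds differ in more than one place, so this gap cannot be read as the effect of any single change.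

Compound 3 `Cn1ncc(Cl)c1-c1cc(C(=O)N[C@@H]2CN[C@H](CC(=O)O)C[C@H]2c2ccc(Cl)c(Cl)c2)oc1Cl` is the next entry and keeps the rest of compound 2 unchanged. It carries carboxy in place of 2-hydroxyethyl on a saturated chain carbon bound to a saturated ring carbon. Among the compounds with values here, the series holds no measured single-change step for comparison, so the expectation below is a judgement with a wide range. A step to a higher number in this assay, moderately beyond the scatter, is expected from the starting point of compound 2 at 600 nM. The expected change is a 4.2-fold higher number from compound 2 to compound 3 (0.62 log units; beyond the scatter). For compound 3 the estimated value is 2500 nM, with an expected range of 800 nM to 10000 nM.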

Compound 3, half-maximal inhibitory concentration: 5120 nM
Compound 3: the middle estimate sits 2.0-fold (0.31 log units) below what was measured; the range from low to high includes it.
By their numbers in this assay, from the lowest: compound 2; then compound 1; then compound 3.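

Carboxy in place of 2-hydroxyethyl on a saturated chain carbon bound to a saturated ring carbon gives, in this assay, an 8.5-fold higher number from compound 2 to compound 3 (0.93 log units; beyond the scatter), the only single-change step among the compounds shown and the first reading of this position with the rest of the molecule held fixed. The groups that leave and enter match in heavy atoms, hydrogen-bond donors and hydrogen-bond acceptors as counted from the structures, and neither carries a net charge by that count, so these counts alone do not separate two compounds that still differ beyond the scatter. No measurement of any property of these groups bears on the step, and its size stays unexplained.

Read one bond further out, the same difference is 3-hydroxypropyl to carboxymethyl, so the end group and the chain length change together and the step cannot assign the higher number to either one; a 2-carboxyethyl chain on the same core would separate the two. On these data alone, compound 1 differs from both compounds in more than one place, so whether the step would hold with the aryl group of compound 1 also remains open.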